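A Fluoro Addition on the Aryl Ring of Compound 1

The compounds below may be only part of what the source reports. "The series", "measured", "known", "first", "only" and "open" are said of these compounds alone.

The measured compounds and their values in a physicochemical assay for lipophilicity, using the shake flask method; on this read-out lower numbers stand for lower lipophilicity and higher numbers for higher lipophilicity:
compound 1, `C[C@H](Oc1cc2cc(C(N)=O)ccc2nc1N)c1cc(F)ccc1-n1cccn1`, 3
compound 2, `C[C@H](Oc1cc2cc(C(N)=O)ccc2nc1N)c1ncc(F)cc1-n1cccn1`, 1.9
compound 3, `C[C@H](Oc1cc2cc(F)cc(F)c2nc1N)c1cc(C(=O)O)ccc1-n1cccn1`, 1

Among these three, compound 1 gives the highest number in this assay. Compound 2 lies next to it, with a value that is lower by a margin beyond the scatter, and compound 3 stands furthest away, lower still. Among the compounds with values here, no two of the measured compounds differ in one place only, so no single-change step between measured compounds can be read off.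

Compound 4, `C[C@H](Oc1cc2cc(C(N)=O)ccc2nc1N)c1cc(F)c(F)cc1-n1cccn1`, is not yet measured. It differs from compound 1 in one place: fluoro in place of hydrogen on an aromatic carbon. The change adds one fluorine atom and removes nothing else.

Within the data shown here, since no measured pair shows a step of this kind, the expectation rests on the change alone. For compound 4 this assay is expected to give 3.2, with a likely range from 2.9 to 3.6. The expected step of a number 0.20 log units higher from compound 1 to compound 4 (within the scatter) is small and upward, close to the scatter of repeated measurements.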

Compound 4, distribution coefficient: 3.2
For compound 4 middle estimate and measured number coincide at the digits printed, within the range that was stated.
By their numbers in this assay, from the lowest: compound 3; then compound 2; then compounds 1 and 4 (each within the scatter of the next).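

In this assay, the series now has its first step at a single place, with fluoro in place of hydrogen on an aromatic carbon that is ortho to a fluoro group and meta to a 1H-pyrazol-1-yl group: a number 0.20 log units higher from compound 1 to compound 4 (within the scatter). At this position, the one added fluorine atom gives two structures that this read-out cannot tell apart. No measurement shown here bears on the reason for this result.

The compounds shown leave open whether another group on this aromatic carbon, such as an amine, a nitrile or a methoxy group, would give a step beyond the scatter. They also leave open whether fluoro in place of hydrogen elsewhere on this ring or on the shared core would give a step of similar size.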